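Aryloxyacetyl replacements on the piperazine amide of compound 1

The source may report more compounds than this note shows. Statements on the series, on what has been measured and on what is new or still open speak of the compounds shown alone.

The series shares the core of compound 1 `CC(C)C[C@H](N)c1cc(C(F)(F)F)ccc1N1CCN(C(=O)C(C)Cc2ccc(Cl)cc2O)CC1` and varies the acyl group on the amide-type nitrogen in the ring. In an assay on HEK293 cells for displacement of a labelled ligand from Melanocortin receptor 4 (Homo sapiens) (a lower number here means a stronger inhibitor, a higher number a weaker inhibitor), compound 1 gives 36 nM, the lowest of the three numbers. Compound 2 `CC(C)C[C@H](N)c1cc(C(F)(F)F)ccc1N1CCN(C(=O)CCC(=O)c2ccc(Cl)cc2)CC1` gives 820 nM in this assay, and compound 3 `Cc1ccc(OCC(=O)N2CCN(c3ccc(C(F)(F)F)cc3[C@@H](N)CC(C)C)CC2)c(C)c1` gives 4000 nM. The step of a 23-fold higher number from compound 1 to compound 2 (1.36 log units; beyond the scatter) is large, the step of a 110-fold higher number from compound 1 to compound 3 (2.05 log units; beyond the scatter) larger still, and the step of a 4.9-fold higher number from compound 2 to compound 3 (0.69 log units; beyond the scatter) is modest.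

Compound 4 `CC(C)C[C@H](N)c1cc(C(F)(F)F)ccc1N1CCN(C(=O)COc2cccc(Cl)c2)CC1` differs from compound 1 as follows: (3-chlorophenoxy)methyl in place of 1-(4-chloro-2-hydroxybenzyl)ethyl on a carbonyl carbon. The most closely related measured step is the change to compound 3, which also puts an aryloxy-methyl group on the carbonyl carbon and also removes the hydrogen-bond donor counted above; that step was a 110-fold higher number from compound 1 to compound 3 (2.05 log units; beyond the scatter). A large rise in the number is therefore expected for compound 4 as well, though possibly less steep than for compound 3, since the ring of compound 4 carries a chlorine as compound 1 does. For compound 4 the expected value in this assay is 1500 nM, within a range of 300 nM to 6000 nM. This estimate corresponds to a step of a 42-fold higher number from compound 1 to compound 4 (1.62 log units; beyond the scatter).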

Compound 4, inhibition constant: 2600 nM
Beside the measured number, compound 4's estimate is 1.7-fold (0.24 log units) below it, and the stated range covers the measured number.
By their numbers in this assay, from the lowest: compound 1; then compound 2; then compounds 4 and 3 (each within the scatter of the next).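

Exchanging the 2,4-dimethylphenyl on the ether oxygen for 3-chlorophenyl gives a 1.5-fold lower number from compound 3 to compound 4 (0.19 log units; within the scatter), so the ring substitution seen here does not separate the two aryloxy-methyl compounds. A chlorine on the ring does not by itself keep the number near that of compound 1: the (3-chlorophenoxy)methyl group, with 0 hydrogen-bond donors, still gives a 72-fold higher number from compound 1 to compound 4 (1.86 log units; beyond the scatter). The ((4-chlorophenyl)carbonyl)methyl group of compound 2 keeps a modest edge over the 3-chlorophenoxy group, with a 3.2-fold higher number from compound 2 to compound 4 (0.50 log units; beyond the scatter).

Nothing measured here accounts for the loss at this position. As far as these compounds go, whether it follows the missing hydroxyl or the ether oxygen stays open, as compound 1 and compound 4 differ in both at once; a hydroxyl on the 3-chlorophenoxy ring, or an amine in place of the ether oxygen, would separate them.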